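Two Aryl Groups, a Third Awaiting Measurement

A few compounds are considered here, and "the series" means these few. Any claim that something is new, unique, unknown or untested is made for them only; others in the source may bear on it.

Measured compounds:
compound 1, `CCC1=C(O)c2c(oc(-c3ccc(C)c(C)c3)cc2=O)C(CC)(CC)C1=O`, 0.71 uM
compound 2, `CCC1=C(O)c2c(oc(-c3ccc(C)c(Cl)c3)cc2=O)C(CC)(CC)C1=O`, 2.15 uM

Of the compounds shown here, two have been tested so far in a functional assay on KBVIN cells (Homo sapiens) for antiproliferative activity, read by sulforhodamine B assay, with a stated time of 3 days; on this read-out higher numbers stand for an effect only at larger amounts of compound and lower numbers for an effect already at smaller amounts. Compound 1 gives 0.71 uM, while compound 2 gives 2.15 uM. Among the compounds with values here, the single one-place step between them, a 3.0-fold higher number from compound 1 to compound 2 (0.48 log units; beyond the scatter), places compound 2 at the highest number of the two.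

Compound 3, `CCC1=C(O)c2c(oc(-c3cccc(C)c3C)cc2=O)C(CC)(CC)C1=O`, has not yet been measured. It differs from compound 2 by 2,3-dimethylphenyl in place of 3-chloro-4-methylphenyl on an aromatic carbon. Within the data shown here, only the step from compound 1 to compound 2 bears on this change, and only in part: it shows what the exchange of methyl and chloro does, but nothing is known about moving a methyl to another aromatic carbon. Compound 3 returns to two methyls, as in compound 1, so a lower number is expected in this assay, with the step estimated as a 2.2-fold lower number from compound 2 to compound 3 (0.33 log units; beyond the scatter). For compound 3 the estimate is 1 uM, in a range from 0.4 uM to 2.6 uM.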

Compound 3, concentration for half-maximal effect: 0.85 uM
Beside the measured number, compound 3's estimate is 1.2-fold (0.07 log units) above it; measured number inside the range.
By their numbers in this assay, from the lowest: compounds 1 and 3 (each within the scatter of the next); then compound 2.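

Compound 3 shows that in this assay the two methyls on the aryl group next to the ring oxygen can sit in a different arrangement without a readable change: 2,3-dimethylphenyl in place of 3,4-dimethylphenyl gives a 1.2-fold higher number from compound 1 to compound 3 (0.08 log units; within the scatter) and so stays level with the earlier dimethyl compound. The exchange of 3-chloro-4-methylphenyl for 2,3-dimethylphenyl gives a 2.5-fold lower number from compound 2 to compound 3 (0.40 log units; beyond the scatter) and thus, among these three compounds, only compound 2, the one carrying chloro, stands apart from the others. Nothing measured on these compounds bears on why the numbers fall this way.

The compounds shown leave open how a chloro would read in the 2,3-arrangement and whether a single methyl on the phenyl ring would hold the number. They also say nothing about a methoxy group, an amine or a carboxylic acid on this aryl ring.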